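A Methyl Cap on a Silent Phenol

The source may report more compounds than this note shows. Statements on the series, on what has been measured and on what is new or still open speak of the compounds shown alone.

In a functional assay on Bel-7402 cells (Homo sapiens) for cytotoxicity, read by MTT assay, with a stated time of 48 h (on this read-out lower numbers stand for stronger inhibition and higher numbers for weaker inhibition), compound 1 `COc1cc(-n2c(-c3ccc(O)cc3)c[nH]c2=O)cc(OC)c1OC` gives > 50000 nM, which is a limit of the assay and not a number. For compound 2 `COc1ccc(-c2c[nH]c(=O)n2-c2cc(OC)c(OC)c(OC)c2)cc1OC`, the entry reads "not determined" (no result reported). Compound 3 `COc1cc(NC(=O)n2cc(-c3ccc(O)cc3)n(-c3cc(OC)c(OC)c(OC)c3)c2=O)cc(OC)c1OC` gives > 50000 nM, again only a limit. Compound 3 therefore has no exact position on the scale, and the set contains no single measured number. The one common feature is a limit: the limit of > 50000 nM in this assay, at which 2 of the 3 values shown sit.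

Compound 4 `COc1ccc(-c2cn(C(=O)Nc3cc(OC)c(OC)c(OC)c3)c(=O)n2-c2cc(OC)c(OC)c(OC)c2)cc1` departs from compound 3 at one place, with methyl in place of hydrogen on an oxygen on an aromatic ring, turning 4-hydroxyphenyl into 4-methoxyphenyl: methyl in place of hydrogen on an oxygen on an aromatic ring. Going by the values given here, no two measured compounds differ in one place, so the data do not size this kind of change directly. With only that shared limit as a guide, little movement is expected in this assay. The estimated at least 1.4-fold lower number from compound 3 to compound 4 (0.15 log units; that floor lies within the scatter) is small and, if a number is reported at all, is expected to point towards stronger inhibition. A further limit remains the likeliest result. Should a number appear, the expected value for compound 4 is 35000 nM, within an estimated range of 10000 nM to 50000 nM.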

Compound 4, half-maximal inhibitory concentration: > 50000 nM
Compound 4: a limit, no number (the forecaster's own chance of this, stated with the estimate: 65%); middle value at least 1.4-fold (0.15 log units) from the limit.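

In this assay compound 4 gives > 50000 nM as a limit of the assay and not a number. Going by these compounds alone, compound 3 also rests on a limit, so no step between compound 3 and compound 4 can be read, and the set stays at one mark: the limit of > 50000 nM in this assay, at which 3 of the 4 values shown sit. The compounds shown leave open whether hydroxy to methoxy changes this read-out at all.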